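Adding one methyl: from compound 3 to compound 4

The compounds below may be only part of what the source reports. "The series", "measured", "known", "first", "only" and "open" are said of these compounds alone.

In a functional assay on the whole organism for inhibition, with Meriones unguiculatus as the target, with a stated time of 1 h (on this read-out lower numbers stand for an effect already at smaller amounts and higher numbers for an effect only at larger amounts of compound), compound 1 `Cc1cc(F)ccc1[C@H]1C[C@@H](N(C)C)CCN1C(=O)N(C)Cc1cc(C(F)(F)F)cc(C(F)(F)F)c1` gives 0.26 mg/kg. Among the measured compounds shown here, compound 3 `Cc1cc(F)ccc1[C@H]1C[C@@H](N2CCCC2)CCN1C(=O)N(C)Cc1cc(C(F)(F)F)cc(C(F)(F)F)c1` gives 0.3 mg/kg, which leaves it level, within the scatter, with the only other number. For the measured compounds named here, the one measured step, a 1.2-fold higher number from compound 1 to compound 3 (0.06 log units; within the scatter), lies at a different place in the structure from the change considered here. Going by the values given here, compound 2 `Cc1cc(F)ccc1[C@H]1C[C@@H](N2CCC2)CCN1C(=O)N(C)[C@H](C)c1cc(C(F)(F)F)cc(C(F)(F)F)c1` carries the same added methyl, but its entry in this assay reads "not determined" (no result reported), so no measured example of this change exists.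

The next compound is compound 4 `Cc1cc(F)ccc1[C@H]1C[C@@H](N2CCCC2)CCN1C(=O)N(C)[C@H](C)c1cc(C(F)(F)F)cc(C(F)(F)F)c1`. Its difference from compound 3 is methyl in place of hydrogen on a saturated chain carbon bound to an amide-type nitrogen and an aromatic carbon.

The measured step offers only weak guidance, since it shows a single change elsewhere staying within the scatter. No step beyond the scatter is therefore expected in this assay, and no firm direction can be expected. The estimated step is a 1.2-fold lower number from compound 3 to compound 4 (0.08 log units; within the scatter). Among the compounds with values here, the range is kept wide because no measured step covers this place. Compound 4 is estimated at 0.25 mg/kg, with an expected range of 0.08 mg/kg to 0.7 mg/kg.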

Compound 4, dose for 50% inhibition: 0.92 mg/kg
For compound 4 the middle estimate is 3.7-fold (0.57 log units) below the measured one, and the stated range ends below it.
By their numbers in this assay, from the lowest: compounds 1 and 3 (each within the scatter of the next); then compound 4.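

In this assay, among the compounds shown here, methyl in place of hydrogen on a saturated chain carbon bound to an amide-type nitrogen and an aromatic carbon gives a 3.1-fold higher number from compound 3 to compound 4 (0.49 log units; beyond the scatter), the first step that lies beyond the scatter, whereas the change of dimethylamino to pyrrolidin-1-yl, a 1.2-fold higher number from compound 1 to compound 3 (0.06 log units; within the scatter), does not. This place therefore responds to the addition of a single carbon, and the response runs towards a larger dose, with compound 4 at 0.92 mg/kg holding the highest number of the three values in this assay; the step is modest and rests on this one pair alone. Nothing shown here gives a reason for the step.

On these data alone, compound 2 carries the same methyl but has no number in this assay, so the steps that involve it cannot be read, and it stays open whether the effect of the methyl holds with dimethylamino or another amine in place of pyrrolidin-1-yl. As far as these compounds go, it is also open whether a larger group at the same carbon, such as ethyl, or the opposite configuration there would move the number further or bring it back.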